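The source may report more compounds than this note shows. Statements on the series, on what has been measured and on what is new or still open speak of the compounds shown alone.

Three compounds built on one shared core were tested in a functional assay on A549 cells (Homo sapiens) for cytotoxicity, read by MTT assay, with a stated time of 48 h; on this read-out higher numbers stand for weaker inhibition and lower numbers for stronger inhibition. Compound 1 `O=c1ccoc2cc(OCc3cn(Cc4ccc(Cl)cc4)nn3)ccc12` carries a 4-chlorobenzyl group on the core. In this assay compound 1 gives > 100000 nM, which is a limit of the assay and not a number. Compound 2 `O=c1ccoc2cc(OCc3cn(Cc4ccc(F)cc4)nn3)ccc12` differs from compound 1 by fluoro in place of chloro on an aromatic carbon. In this assay compound 2 gives > 100000 nM, again a limit rather than a measured number. Compound 3 `O=c1ccoc2cc(OCc3cn(Cc4ccccc4Cl)nn3)ccc12` differs from compound 1 by 2-chlorophenyl in place of 4-chlorophenyl on a saturated chain carbon bound to an aromatic nitrogen. In this assay compound 3 gives > 100000 nM, once more a limit of the assay.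

With all three values at a limit, none of the steps between them can be sized: a step that the two limits leave unreadable from compound 1 to compound 2, a step that the two limits leave unreadable from compound 1 to compound 3 and a step that the two limits leave unreadable from compound 2 to compound 3. What the data do show is the limit of > 100000 nM in this assay, at which 3 of the 3 values shown sit.

Compound 4 `O=c1ccoc2cc(OCc3cn(Cc4ccccc4F)nn3)ccc12` has not yet been measured. It differs from compound 3 by fluoro in place of chloro on an aromatic carbon. For the measured compounds named here, this is the same kind of change as the one from compound 1 to compound 2, but at a different place: there the fluoro sits para to a large group, here ortho to a large group. Since compound 3 gives > 100000 nM and the change from compound 1 to compound 2 left the value at the limit, the step from compound 3 to compound 4 is expected to be about a step that the limit leaves unreadable from compound 3 to compound 4. Compound 4 is therefore estimated to give roughly 200000 nM in this assay, with an expected range from 100000 nM to 500000 nM, most likely reported again only as a limit.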

Compound 4, half-maximal inhibitory concentration: 10800 nM
Beside the measured number, compound 4's estimate is 19-fold (1.27 log units) above it, and the stated range ends above it.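

In this assay, for the compounds shown here, fluoro in place of chloro on the 2-chlorophenyl gives an at least 9.2-fold lower number from compound 3 to compound 4 (0.96 log units; beyond the scatter), whereas the same swap on the 4-chlorophenyl, from compound 1 to compound 2, gives no step that can be read, so this series shows no readable carry-over of the change from one setting to the other. Moving the fluoro from the 4-fluorophenyl to the 2-fluorophenyl gives an at least 9.2-fold lower number from compound 2 to compound 4 (0.96 log units; beyond the scatter), and the combined change from the 4-chlorophenyl gives an at least 9.2-fold lower number from compound 1 to compound 4 (0.96 log units; beyond the scatter), which places compound 4 alone at a measured number, while the steps among compound 1, compound 2 and compound 3 cannot be read. This does not show the full size of any of these steps, nor whether the swap does anything at all on the 4-chlorophenyl, because the other values rest at a limit: the limit of > 100000 nM in this assay, at which 3 of the 4 values shown sit.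

The compounds shown leave open how a methoxy group, an amine or a nitrile would read in place of the fluoro on the 2-fluorophenyl. Going by these compounds alone, they also leave open whether a longer chain in place of the single saturated chain carbon would keep the value of compound 4, which is the only one of the four values that is a measured number.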